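The compounds below may be only part of what the source reports. "The series", "measured", "known", "first", "only" and "open" are said of these compounds alone.

Measured in a functional assay (aorta) with Oryctolagus cuniculus as the target; on this read-out lower numbers stand for tighter binding and higher numbers for weaker binding:
- Compound 1 `COc1cc(C#N)ccc1OCCCN1CCC(C(c2ccc(F)cc2)c2ccc(F)cc2)CC1`: 2 nM
- Compound 2 `CC(=O)c1ccc(OCCCN2CCC(C(c3ccc(F)cc3)c3ccc(F)cc3)CC2)cc1`: 2.51 nM
- Compound 3 `Fc1ccc(OCCCN2CCC(C(c3ccc(F)cc3)c3ccc(F)cc3)CC2)cc1`: 1.26 nM

Compound 3 gives 1.26 nM, a value within the scatter of the other two. The steps that reach it are a 1.6-fold lower number from compound 1 to compound 3 (0.20 log units; within the scatter) and a 2.0-fold lower number from compound 2 to compound 3 (0.30 log units; within the scatter).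

Compound 4 `Fc1ccc(C(c2ccc(F)cc2)C2CCN(CCCOc3ccc(Cl)cc3)CC2)cc1` differs from compound 3 by chloro in place of fluoro on an aromatic carbon, para to a large group. Among the compounds with values here, no measured step makes this exchange, so the evidence is indirect. The closest case is at the same place, a 2.0-fold lower number from compound 2 to compound 3 (0.30 log units; within the scatter), with fluoro in place of acetyl. The remaining step, a 1.3-fold higher number from compound 1 to compound 2 (0.10 log units; within the scatter), replaces the whole aryl group, and it too stays within the scatter. None of the three measured steps leaves the scatter in this assay, so no real shift is expected from this smaller exchange.

The expected step is a 1.3-fold higher number from compound 3 to compound 4 (0.10 log units; within the scatter), which would not go beyond the scatter. For compound 4 the estimated value is 1.6 nM, with an expected range of 0.6 nM to 4 nM.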

Compound 4, dissociation constant: 2 nM
Compound 4: middle estimate off by 1.3-fold (0.10 log units), on the low side; the measured number falls inside the stated range.
By their numbers in this assay, from the lowest: compounds 3, 1, 4 and 2 (each within the scatter of the next).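

In this assay the halogen exchange can now be read directly: going from 4-fluorophenoxy to 4-chlorophenoxy gives a 1.6-fold higher number from compound 3 to compound 4 (0.20 log units; within the scatter) and so stays inside the scatter at this place, para to a large group. The same end group also compares with the earlier ones, with a 1.3-fold lower number from compound 2 to compound 4 (0.10 log units; within the scatter) for chloro in place of acetyl and no change at the digits printed from compound 1 to compound 4 (within the scatter) for the exchange of the whole aryl group, so all four aryl ends shown lie within the scatter of one another. No evidence at hand bears on why this position responds so little to these exchanges.

From the compounds shown here alone, it remains open whether any group at this place would move the number beyond the scatter, such as an amine, a hydroxyl or a carboxylic acid. Also open, going by these compounds, is how a longer chain in the shared core would read in this assay.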